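The compounds below may be only part of what the source reports. "The series", "measured", "known", "first", "only" and "open" are said of these compounds alone.

In a physicochemical assay for lipophilicity, read by HPLC, at pH 7.5 (on this read-out higher numbers stand for higher lipophilicity and lower numbers for lower lipophilicity), compound 1 `CC[C@@H](Nc1c(C#N)c(-c2ccc(-c3cccc(C)c3)cc2)nc2cnccc12)C(N)=O` gives 3 and compound 2 `CC[C@@H](Nc1c(C#N)c(-c2ccc(-c3cccc(Cl)c3OC)cc2)nc2cnccc12)C(N)=O` gives 3.1 while compound 3 `CC[C@@H](Nc1c(C#N)c(-c2ccc(-c3ccc(OC)cc3)cc2)nc2cnccc12)C(N)=O` gives 2.7 on this scale. Compound 3 thus sits within the scatter of compound 1 and apart only from compound 2. Compound 4 `CC[C@@H](Nc1c(C#N)c(-c2ccc(-c3cnccc3C)cc2)nc2cnccc12)C(N)=O` carries 4-methylpyridin-3-yl in place of 4-methoxyphenyl on an aromatic carbon at the same place. Within the data shown here, the steps that bear on this are a number 0.10 log units higher from compound 1 to compound 2 (within the scatter) and a number 0.30 log units lower from compound 1 to compound 3 (within the scatter) and a number 0.40 log units lower from compound 2 to compound 3 (beyond the scatter) and the last of these is only modest. None of them brings in a ring with a hetero atom, so they guide the size only loosely. In this assay a lower number is expected, with an estimated step of a number 0.50 log units lower from compound 3 to compound 4 (beyond the scatter) as the working figure. The estimate for compound 4 is 2.2 with an expected range from 1.8 to 2.6 for now.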

Compound 4, distribution coefficient: 2
Compound 4: the middle estimate sits 0.20 log units above what was measured, and the stated range covers the measured number.
By their numbers in this assay, from the lowest: compound 4; then compounds 3, 1 and 2 (each within the scatter of the next, the first and the last beyond it).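

At this position, on an aromatic carbon para to a large group, a ring with 1 hetero atom separates from all three carbon-only aryl groups in this assay: a number 0.70 log units lower from compound 3 to compound 4 (beyond the scatter), a number 1.00 log units lower from compound 1 to compound 4 (beyond the scatter) and a number 1.10 log units lower from compound 2 to compound 4 (beyond the scatter). Compound 4 thus holds the lowest number of the set, and the largest step among the carbon-only rings is smaller than any of these. Nothing at hand explains the size of these steps.

4-methoxyphenyl and 4-methylpyridin-3-yl differ in both ring and substituent, so the share of the ring nitrogen in the step stays open. From the compounds shown here alone, how a carboxylic acid or a primary amine on this ring would read also stays open.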